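The source may hold more compounds than are shown below. What is called first, only, known or untested is meant among the compounds shown, and "the series" means these compounds.

Of the compounds shown here, three sharing one core have been measured in a functional assay on A549 cells (Homo sapiens) for cytotoxicity, read by colorimetric assay and MTT assay, with a stated time of 3 days, tested at 20 uM; on this read-out higher numbers stand for a weaker effect at the one concentration tested and lower numbers for a stronger effect. Compound 1 `O=C1COc2ccc(-c3[nH]c(-c4ccc(C(F)(F)F)cc4)nc3-c3ccccc3)cc2N1` gives 21.7%, the strongest effect of the three. Compound 2 `COc1ccc(-c2nc(-c3ccccc3)c(-c3ccc4c(c3)NC(=O)CO4)[nH]2)cc1` gives 38.1%. For the measured compounds named here, the only single-point step among the measured compounds links these two: a number 16.4 percentage points higher from compound 1 to compound 2 (beyond the scatter), a weakening of the effect. Compound 3 `O=C1COc2ccc(-c3nn(-c4ccc(F)cc4)cc3-c3ccccc3)cc2N1` gives 56.4%, the highest number of the three, and its gaps to compound 2 and to compound 1 both lie beyond the scatter, so on these numbers compound 3 has the weakest effect of the measured set.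

Compound 4 `COc1ccc(-n2cc(-c3ccccc3)c(-c3ccc4c(c3)NC(=O)CO4)n2)cc1` differs from compound 3 in one place: methoxy in place of fluoro on an aromatic carbon. Going by the values given here, no measured step shows exactly this exchange. The nearest comparison is the replacement of trifluoromethyl by methoxy on an aromatic carbon of the same ring, seen in a number 16.4 percentage points higher from compound 1 to compound 2 (beyond the scatter), where the number rose modestly. That step bears on the present one only loosely, since what leaves here is fluoro rather than trifluoromethyl. A smaller rise, or none beyond the scatter, is therefore the reasonable expectation, and the step of a number 7.6 percentage points higher from compound 3 to compound 4 (within the scatter) is the estimated size of it. For compound 4 the expected value in this assay is 64%, within a range from 46% to 84%.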

Compound 4, a percentage reported as activity, at one concentration (the size of the read-out at that concentration, not a potency): 42.6%
Beside the measured number, compound 4's estimate is 21.4 percentage points above it; the whole stated range lies above it.
By their numbers in this assay, from the lowest: compound 1; then compounds 2 and 4 (each within the scatter of the next); then compound 3.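

The change from 4-fluorophenyl to 4-methoxyphenyl goes with a number 13.8 percentage points lower from compound 3 to compound 4 (beyond the scatter) in this assay, so on the core of compound 3 this position responds to the group it carries, and here methoxy gives the stronger effect. This is new. For the compounds shown here, the only earlier step with methoxy entering ran the other way, a number 16.4 percentage points higher from compound 1 to compound 2 (beyond the scatter), where it replaced trifluoromethyl on a different core; taken together, the two steps show that methoxy does not push the number in one fixed direction, and that its result depends on the group it replaces, the core, or both. Nothing available here explains why these two steps run in opposite directions.

The compounds shown cannot separate those two possibilities, since no pair makes the change from fluoro to methoxy on the core of compound 1, or the change from trifluoromethyl to methoxy on the core of compound 3. Going by these compounds, it also remains open whether a hydroxyl group, an amine or a longer chain such as ethoxy at this same aromatic carbon would lower the number further or raise it again.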